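The source may hold more compounds than are shown below. What is called first, only, known or untested is meant among the compounds shown, and "the series" means these compounds.

In a functional assay on NCI-H460 cells (Homo sapiens) (a higher number here means a weaker inhibitor, a lower number a stronger inhibitor), compound 1 `COc1cc(NC(C)CCCNC(=O)NCCCCCO)c2ncccc2c1` gives 2000 nM, the lower of the two exact numbers in the series, and compound 3 `COc1cc(NC(C)CCCNC(=O)NCCNC(=O)NCCCC(C)Nc2cc(OC)cc3cccnc23)c2ncccc2c1` gives 18000 nM. Compound 2 `COc1cc(NC(C)CCCNC(=O)N(CCO)CCO)c2ncccc2c1` reads > 100000 nM, which is a limit of the assay and not a number. Compound 4 `COC(=O)NCCCC(C)Nc1cc(OC)cc2cccnc12` differs from compound 1 on the carbonyl carbon: methoxy in place of (5-hydroxypentyl)amino on a carbonyl carbon. Among the compounds with values here, the single measured step that also removes (5-hydroxypentyl)amino there is an at least 50-fold higher number from compound 1 to compound 2 (1.69 log units; beyond the scatter), large and beyond the scatter. On that one step, a higher number is expected in this assay, though a smaller rise than that step shows. The expected change is a 7.5-fold higher number from compound 1 to compound 4 (0.88 log units; beyond the scatter). For compound 4 the estimated value is 15000 nM, with an expected range of 3000 nM to 60000 nM.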

Compound 4, half-maximal inhibitory concentration: > 100000 nM
Compound 4: a limit, no number (the forecaster's own chance of this, stated with the estimate: 15%); at least 6.6-fold (0.82 log units) between middle value and limit.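

In this assay, methoxy in place of (5-hydroxypentyl)amino on a carbonyl carbon gives an at least 50-fold higher number from compound 1 to compound 4 (1.69 log units; beyond the scatter), so this change, unlike that to bis(2-hydroxyethyl)amino, also removes the amide-type nitrogen from that carbonyl carbon and still gives no readable number. From the compounds shown here alone, compound 4 stands at a limit of the assay, not a number, so the full size of this step stays unknown. Compound 2 and compound 4 cannot be ordered, and the step between them cannot be read: the limit of > 100000 nM in this assay, at which 2 of the 4 values shown sit.

Open, going by these compounds, is whether the hydroxyl or the pentyl chain of compound 1 matters more. A plain pentylamino group or a longer hydroxyalkylamino chain on that carbonyl carbon would separate the two.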